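Compound 3 as a simpler aryl variant of compound 2

The source may report more compounds than this note shows. Statements on the series, on what has been measured and on what is new or still open speak of the compounds shown alone.

Measured compounds in a functional assay on HepG2 cells (Homo sapiens) for antiproliferative activity, read by MTT assay, with a stated time of 48 h; a higher number here means a weaker inhibitor, a lower number a stronger inhibitor:
Compound 1 `CN(C)c1ccc(NC(=O)Nc2cccc(CNc3nccnc3Cl)c2)cc1`: > 40000 nM (a limit of the assay)
Compound 2 `O=C(Nc1cccc(CNc2nccnc2Cl)c1)Nc1ccc(Cl)cc1Br`: 6720 nM

Among the measured compounds shown here, compound 2 holds the only actual number in this assay, since the entry for compound 1 is a limit. Compound 3 `O=C(Nc1cccc(CNc2nccnc2Cl)c1)Nc1ccccc1Cl` changes one place, on an amide-type nitrogen, where 2-chlorophenyl stands in place of 2-bromo-4-chlorophenyl: 2-chlorophenyl in place of 2-bromo-4-chlorophenyl on an amide-type nitrogen. For the measured compounds named here, the one measured step at this place is an at least 5.9-fold lower number from compound 1 to compound 2 (0.77 log units; beyond the scatter), with 2-bromo-4-chlorophenyl in place of 4-(dimethylamino)phenyl. That step involves a different incoming group, so it guides the present change only loosely. Compound 3 still carries a chlorinated phenyl, so only a small shift towards a weaker inhibitor is expected in this assay. The expected change is a 2.1-fold higher number from compound 2 to compound 3 (0.32 log units; beyond the scatter). For compound 3 the estimated value is 14000 nM, with an expected range of 4500 nM to 40000 nM.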

Compound 3, half-maximal inhibitory concentration: 8560 nM
Compound 3: middle estimate off by 1.6-fold (0.21 log units), on the high side, and the stated range covers the measured number.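

In this assay, 2-chlorophenyl in place of 2-bromo-4-chlorophenyl on the amide-type nitrogen gives a 1.3-fold higher number from compound 2 to compound 3 (0.11 log units; within the scatter), so compound 2 and compound 3 cannot be told apart here, and this position accepts the simpler aryl group without a measurable change. Replacing 4-(dimethylamino)phenyl with 2-chlorophenyl gives an at least 4.6-fold lower number from compound 1 to compound 3 (0.66 log units; beyond the scatter), so a second halogen-bearing aryl group now stands apart from the dimethylamino compound, and the earlier step no longer rests on compound 2 alone. The true size of both steps from compound 1 remains unknown, as its entry is a limit and not a number: the limit of > 40000 nM in this assay, at which 1 of the 3 values shown sits.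

The compounds shown leave open how an unsubstituted phenyl, or a phenyl carrying a methoxy group or a carboxylic acid, would read at this position. They also leave open whether the chlorine of 2-chlorophenyl is needed at all.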